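This account rests on a few compounds, and the source may have more. Where it says the series, first, only, none or still open, it means among the compounds named here.

In a functional assay on HCT-116 cells (Homo sapiens) for antiproliferative activity, read by MTT assay, with a stated time of 72 h (a lower number here means a stronger inhibitor, a higher number a weaker inhibitor), compound 1 `O=C1COc2ccc(-c3cnc(Cl)c(NS(=O)(=O)c4ccc(F)cc4)c3)cc2N1C1CCCCC1`, with cyclohexyl on an amide-type nitrogen in a ring, gives > 40000 nM, which is a limit of the assay and not a number. Compound 2 `CC(C)N1C(=O)COc2ccc(-c3cnc(Cl)c(NS(=O)(=O)c4ccc(F)cc4)c3)cc21`, with isopropyl in that place, gives 18900 nM. For the measured compounds named here, that makes an at least 2.1-fold lower number from compound 1 to compound 2 (0.32 log units; beyond the scatter), the only measured step at this nitrogen. Compound 3 `CC(C)N1C(=O)COc2ccc(-c3cccc(NS(=O)(=O)c4ccc(F)cc4)c3)cc21`, which also carries isopropyl there, gives 22600 nM. Going by the values given here, this value lies within the usual scatter of the one for compound 2, so the two cannot be told apart.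

Compound 4 `O=C1COc2ccc(-c3cccc(NS(=O)(=O)c4ccc(F)cc4)c3)cc2N1c1ccc(F)cc1` keeps the rest of compound 3 but has 4-fluorophenyl in place of isopropyl on the amide-type nitrogen in a ring: 4-fluorophenyl in place of isopropyl on an amide-type nitrogen in a ring. Among the compounds with values here, the incoming ring resembles cyclohexyl more than isopropyl in size, and the one relevant step, an at least 2.1-fold lower number from compound 1 to compound 2 (0.32 log units; beyond the scatter), went to a lower number on moving from cyclohexyl to isopropyl. Read in reverse, that step suggests a move toward a higher number in this assay, meaning a weaker inhibitor. A single step with an open-ended limit is thin support, so only a small change is expected, perhaps no larger than the scatter. The estimate amounts to a 1.4-fold higher number from compound 3 to compound 4 (0.15 log units; within the scatter). For compound 4, the expected value is about 32000 nM, with an estimated range from 14000 nM to 55000 nM.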

Compound 4, half-maximal inhibitory concentration: > 40000 nM
Compound 4: a limit, no number (the forecaster's own chance of this, stated with the estimate: 35%); middle value at least 1.2-fold (0.09 log units) from the limit.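

Among the compounds shown, only compound 4 carries an aromatic ring on the amide-type nitrogen in a ring, and in this assay putting 4-fluorophenyl in place of isopropyl gives an at least 1.7-fold higher number from compound 3 to compound 4 (0.24 log units; that floor lies within the scatter). That figure is only a floor, and the floor itself lies within the scatter, so this step alone cannot establish a real loss of activity, although it gives no sign of a lower number with the aromatic ring at this position. The reading for compound 4 is a limit and not a number, and the true size of the step cannot be read from it: the limit of > 40000 nM in this assay, at which 2 of the 4 values shown sit.

On these data alone, it remains open whether the ring itself or its fluorine matters, and how a plain phenyl, a methyl or a longer chain ending in an amine on this nitrogen would read in this assay. Equally open, as far as these compounds go, is whether any group at this position could bring the number far below those of compound 2 and compound 3, which lie within the scatter of each other.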